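Compound 4: a step from an unmeasured start

The source may hold more compounds than are shown below. What is called first, only, known or untested is meant among the compounds shown, and "the series" means these compounds.

In a functional assay on KB cells (Homo sapiens) for cytotoxicity, read by MTT assay, with a stated time of 72 h (a higher number here means a weaker inhibitor, a lower number a stronger inhibitor), compound 3 (`COc1ccc(Nc2nc3ccccc3nc2S(=O)(=O)c2ccc(Br)cc2)cc1`) stands at "not determined" (no result reported), so the step has no measured start. The change to compound 4 (`Nc1cccc(Nc2nc3ccccc3nc2S(=O)(=O)c2ccc(Br)cc2)c1`) is 3-aminophenyl in place of 4-methoxyphenyl on a nitrogen on an aromatic ring. Compound 1 (`Nc1cccc(Nc2nc3ccccc3nc2S(=O)(=O)c2ccccc2)c1`) gives 4290 nM and compound 2 (`COc1ccc(S(=O)(=O)c2nc3ccccc3nc2Nc2cccc(N)c2)cc1`) gives 4960 nM, and both carry the 3-aminophenyl group that enters here. For the measured compounds named here, the only measured step, a 1.2-fold higher number from compound 1 to compound 2 (0.06 log units; within the scatter), is methoxy in place of hydrogen on an aromatic carbon, not this exchange, and it stays within the scatter. No size or direction of step can be expected in this assay, so the estimate rests on those two values. Compound 4 is expected at 4000 nM, with an estimated range of 1500 nM to 10000 nM.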

Compound 4, half-maximal inhibitory concentration: 5340 nM
For compound 4 the middle estimate is 1.3-fold (0.13 log units) below the measured one; the measured number falls inside the stated range.
By their numbers in this assay, from the lowest: compounds 1, 2 and 4 (each within the scatter of the next).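

In this assay bromo in place of methoxy on an aromatic carbon gives a 1.1-fold higher number from compound 2 to compound 4 (0.03 log units; within the scatter) and bromo in place of hydrogen on an aromatic carbon gives a 1.2-fold higher number from compound 1 to compound 4 (0.10 log units; within the scatter) on the 3-aminophenyl compounds. Hydrogen, methoxy and bromo at this place therefore give values within the scatter of one another in compounds 1, 2 and 4. No measurement bearing on this result is available.

The exchange of (4-methoxyphenyl)amino for (3-aminophenyl)amino cannot be read, as compound 3 has no result. Also open, going by these compounds, is whether a carboxylic acid or an amine at this aromatic carbon would depart from these values.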